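Amide aryl swap: from methoxyphenyl to acetylphenyl

This account rests on a few compounds, and the source may have more. Where it says the series, first, only, none or still open, it means among the compounds named here.

The series shares one core, varied only in the aryl group on the amide nitrogen. Compound 1 `Cc1cccc(NC(=O)CSc2nnc(-c3ccoc3C)n2Cc2ccco2)c1` carries a 3-methylphenyl there; in a functional assay on CHO cells for antagonist activity at Orexin/Hypocretin receptor type 1 (Homo sapiens), read by FLIPR and calcium flux (a higher number here means a weaker inhibitor, a lower number a stronger inhibitor), compound 1 gives 2510 nM. Compound 2 `COc1ccccc1NC(=O)CSc1nnc(-c2ccoc2C)n1Cc1ccco1` carries a 2-methoxyphenyl instead. For compound 2 this assay reports only a limit, > 15800 nM. Compound 2 therefore stands at the weak end of the two values shown, the step of an at least 6.2-fold higher number from compound 1 to compound 2 (0.79 log units; beyond the scatter) recording the loss, whose size is known only as a lower bound because the value of compound 2 sits at the limit of > 15800 nM in this assay, at which 1 of the 2 values shown sits.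

Compound 3 `CC(=O)c1cccc(NC(=O)CSc2nnc(-c3ccoc3C)n2Cc2ccco2)c1` is not yet measured and differs from compound 2 by 3-acetylphenyl in place of 2-methoxyphenyl on an amide-type nitrogen. Among the compounds with values here, the only measured step touching this position is an at least 6.2-fold higher number from compound 1 to compound 2 (0.79 log units; beyond the scatter); it shows that a 2-methoxyphenyl costs potency against the 3-methylphenyl of compound 1, and a 3-acetylphenyl resembles that pattern more than the 2-methoxyphenyl. A recovery is expected, the step of an at least 2.6-fold lower number from compound 2 to compound 3 (0.42 log units; beyond the scatter) being estimated as a modest move to stronger inhibition, though compound 3 may still sit near the limit. Compound 3 is expected to give about 6000 nM in this assay, within 1500 nM to 20000 nM.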

Compound 3, inhibition constant: 3160 nM
The estimate for compound 3 lay 1.9-fold (0.28 log units) above the measured number, within the range that was stated.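

In this assay, the 3-acetylphenyl on the amide-type nitrogen restores what the 2-methoxyphenyl lost, with an at least 5.0-fold lower number from compound 2 to compound 3 (0.69 log units; beyond the scatter), so the loss seen earlier does not extend to every aryl group bearing an oxygen substituent. Compound 2 has only a limit, so the size of this step is known only as a lower bound: the limit of > 15800 nM in this assay, at which 1 of the 3 values shown sits. Acetyl in place of methyl on an aromatic carbon leaves the reading within the usual scatter, with a 1.3-fold higher number from compound 1 to compound 3 (0.10 log units; within the scatter), so the two groups cannot be told apart at this position and the position accepts a carbonyl-bearing substituent as well as a plain methyl.

Compound 2 differs from compound 1 and from compound 3 both in the substituent and in where it sits on the phenyl ring, and the compounds shown do not separate these two changes. Also open, going by these compounds, is how an amine, a carboxylic acid or a longer chain in place of the acetyl would read in this assay, and whether any such group would give a clearly stronger inhibitor than compound 1 and compound 3.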